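A bromo swap on an unmeasured nitro compound

This account rests on a few compounds, and the source may have more. Where it says the series, first, only, none or still open, it means among the compounds named here.

Entries so far in a functional assay on MCF7 cells (Homo sapiens) for cytotoxicity, read by MTT assay, with a stated time of 48 h (a lower number here means a stronger inhibitor, a higher number a weaker inhibitor), are these:
- compound 1 `CCn1c(/C=C2/C(=O)Nc3ccccc32)nc2ccccc21` gives "not determined" (no result reported) as its entry
- compound 2 `CCn1c(/C=C2/C(=O)Nc3ccc(C)cc32)nc2ccccc21` gives > 50000 nM as its entry
- compound 3 `Cn1c(/C=C2/C(=O)Nc3ccc([N+](=O)[O-])cc32)nc2ccccc21` gives "not determined" (no result reported) as its entry

Compound 3 has the entry "not determined" (no result reported) and so stands without a single number. Compound 2 has > 50000 nM as its entry, which is a limit of the assay and not a number.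

The change to follow is bromo in place of nitro on an aromatic carbon and in words it is bromo in place of nitro on an aromatic carbon. The structure of compound 4 is `Cn1c(/C=C2/C(=O)Nc3ccc(Br)cc32)nc2ccccc21` and its measurement is still to come.

Going by the values given here, no measured pair shows what this swap does in this assay and compound 3 offers no number to step from, so no definite step in either direction is expected. The estimate therefore leans only on compound 2 and its limit of > 50000 nM as the one figure in hand. Compound 4 is expected at 30000 nM with 8000 nM to 60000 nM as the estimated range.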

Compound 4, half-maximal inhibitory concentration: > 50000 nM
Compound 4: only a limit was reported; the forecaster's own chance of this, stated with the estimate: 50%; middle value at least 1.6-fold (0.22 log units) away from the limit.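

In this assay compound 4 gives > 50000 nM, which is a limit of the assay and not a number. Going by these compounds alone, compound 3 has no single number, so no step to compound 4 can be read. The compounds shown leave open what bromo in place of nitro does to cytotoxicity, since the only entries in hand are limits: the limit of > 50000 nM in this assay, at which 2 of the 4 values shown sit.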